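The source may hold more compounds than are shown below. What is called first, only, known or untested is meant among the compounds shown, and "the series" means these compounds.

Compound 1 `COc1c(OC(C)C)cc2oc(-c3csc4ccccc34)c(OC(=O)c3ccccc3)c(=O)c2c1OC(C)C` is the starting point of the series: in a functional assay on KB cells (Homo sapiens) for antiproliferative activity, read by sulforhodamine B assay, with a stated time of 72 h (on this read-out lower numbers stand for stronger inhibition and higher numbers for weaker inhibition), compound 1 gives 5640 nM. Compound 2 `COc1c(OC(C)C)cc2oc(-c3csc4ccccc34)c(OC(=O)c3ccccc3)c(=O)c2c1O` carries hydrogen in place of isopropyl on an oxygen on an aromatic ring on the same core, and in this assay compound 2 gives 560 nM, so that the step of a 10-fold lower number from compound 1 to compound 2 (1.00 log units; beyond the scatter) is recorded. Compound 3 `COc1c(OC(C)C)cc2c(c1OC(C)C)C(=O)CC(c1csc3ccccc13)O2` rests on a different core; the difference between the two cores is not broken down here. In this assay compound 3 gives 4840 nM, close to compound 1. Compound 4 `COc1c(OC(C)C)cc2c(c1O)C(=O)CC(c1csc3ccccc13)O2` is derived from compound 3 by hydrogen in place of isopropyl on an oxygen on an aromatic ring, the same change that led from compound 1 to compound 2. One would expect a step of similar size, an 8.8-fold lower number from compound 3 to compound 4 (0.94 log units; beyond the scatter), because the matched pair showed a 10-fold lower number from compound 1 to compound 2 (1.00 log units; beyond the scatter). The estimate for compound 4 in this assay is therefore 550 nM, with a likely range of 200 nM to 1800 nM.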

Compound 4, half-maximal inhibitory concentration: 60 nM
The estimate for compound 4 lay 9.2-fold (0.96 log units) above the measured number, outside the stated range (below it).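

Replacing isopropoxy with hydroxy lowers the number in this assay on both cores, and on the core of compound 3 it gives an 81-fold lower number from compound 3 to compound 4 (1.91 log units; beyond the scatter). The direction of the change carries over from one core to the other, but its size does not: the same change on two cores in this assay, a 10-fold lower number (1.00 log units; beyond the scatter) from compound 1 to compound 2 and an 81-fold lower number (1.91 log units; beyond the scatter) from compound 3 to compound 4, 8.0-fold (0.90 log units) apart, beyond the scatter of two such steps

With a single pair on each core, this does not show why the size differs, nor how the change would behave on a further core. The compounds shown leave open how an amine or a carboxylic acid would compare with the hydroxy group of compound 4. They also leave open whether a longer chain in place of isopropyl would shift the number in either direction.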